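Amide nitrogen substituent swap in a dichlorophenyl enone series

The compounds below may be only part of what the source reports. "The series", "measured", "known", "first", "only" and "open" are said of these compounds alone.

Compound 1 `C=C(CC)C(=O)c1ccc(OCC(=O)NCCCN2CCCC2=O)c(Cl)c1Cl` carries a 3-(2-oxopyrrolidin-1-yl)propyl group on the amide nitrogen. In a functional assay on CLL cells (Homo sapiens) for cytotoxicity, read by MTT assay, with a stated time of 48 h (a higher number here means that more compound is needed for the effect, a lower number that less compound is needed), compound 1 gives 13800 nM. Among the compounds with values here, compound 2 `C=C(CC)C(=O)c1ccc(OCC(=O)Nc2ccc(O)c([N+](=O)[O-])c2)c(Cl)c1Cl`, the only other measured member, gives 7400 nM in this assay. The two numbers lie within the usual scatter of each other, so compound 1 and compound 2 cannot be separated on these data. Compound 3 `C=C(CC)C(=O)c1ccc(OCC(=O)Nc2ccc(C#N)cc2)c(Cl)c1Cl` is the next candidate for this assay. Compared with compound 1 it differs by 4-cyanophenyl in place of 3-(2-oxopyrrolidin-1-yl)propyl on an amide-type nitrogen. No step between measured compounds covers this exchange, so the expectation rests on the two numbers shown. Since compound 2 gives 7400 nM with an aryl group on the same amide nitrogen, compound 3 is estimated at 7000 nM, with a range of 2500 nM to 20000 nM. The step of a 2.0-fold lower number from compound 1 to compound 3 (0.29 log units; within the scatter) is expected to be small, toward a lower number, and possibly not beyond the scatter.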

Compound 3, half-maximal effective concentration: 7800 nM
The estimate for compound 3 lay 1.1-fold (0.05 log units) below the measured number; the range from low to high includes it.
By their numbers in this assay, from the lowest: compounds 2, 3 and 1 (each within the scatter of the next).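

In this assay, within the data shown here, placing 4-cyanophenyl in place of 3-(2-oxopyrrolidin-1-yl)propyl on an amide-type nitrogen gives a 1.8-fold lower number from compound 1 to compound 3 (0.25 log units; within the scatter), the first direct step at this place. Compound 1 and compound 3 therefore cannot be separated, even though a five-membered non-aromatic ring with 1 hetero atom leaves and a six-membered aromatic ring of carbon only enters with a triple bond. No separate measurement is available to account for this result.

Going by these compounds, whether any group on this amide nitrogen can give a number beyond the scatter stays open, for example a chain ending in a tertiary amine, a carboxylic acid or an unsubstituted phenyl. On these data alone, the core of compound 1 is shared by all three compounds, so what its parts contribute also stays open.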